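The source may hold more compounds than are shown below. What is called first, only, known or untested is meant among the compounds shown, and "the series" means these compounds.

Of the compounds shown here, three sharing one core have been tested in a functional assay on SK-MEL-28 cells (Homo sapiens) for cytotoxicity, read by MTT assay; a higher number here means a weaker inhibitor, a lower number a stronger inhibitor. Compound 1 `O=S(=O)(NCCCNc1nccc(-c2c(-c3cccc(F)c3)nc3sccn23)n1)c1ccc(C(F)(F)F)cc1` gives 11700 nM. Compound 2 `O=S(=O)(NCCCNc1nccc(-c2c(-c3cccc(F)c3)nc3sccn23)n1)c1ccccc1` gives 6850 nM, and compound 3 `O=S(=O)(NCCNc1nccc(-c2c(-c3cccc(F)c3)nc3sccn23)n1)c1ccc(C(F)(F)F)cc1` gives 8450 nM. Compound 2 has the lowest of the three numbers, yet both of its neighbours sit within the usual scatter, so no order among them can be claimed. Going by the values given here, the only single-point change among the measured compounds is a 1.7-fold lower number from compound 1 to compound 2 (0.23 log units; within the scatter), a change on the aromatic ring of the phenylsulfonyl part.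

Compound 4 `O=C(NCCNc1nccc(-c2c(-c3cccc(F)c3)nc3sccn23)n1)c1c(F)cccc1F` differs from compound 2 in another way: ((2,6-difluorophenyl)carbonyl)amino in place of ((phenylsulfonyl)amino)methyl on a saturated chain carbon, two bonds along the chain from a nitrogen on an aromatic ring. Among the compounds with values here, no measured step touches this kind of exchange; the step from compound 1 to compound 2 concerns a different part of the molecule, and compounds 2 and 3 differ in chain length without a step being computed for them. With nothing pointing either way, compound 4 is expected to stay close to compound 2, giving an estimated 7000 nM, in a range from 3000 nM to 16000 nM. This corresponds to an expected step of a 1.0-fold higher number from compound 2 to compound 4 (0.01 log units; within the scatter), not beyond the scatter.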

Compound 4, half-maximal inhibitory concentration: 11400 nM
Beside the measured number, compound 4's estimate is 1.6-fold (0.21 log units) below it; the measured number falls inside the stated range.
By their numbers in this assay, from the lowest: compounds 2, 3, 4 and 1 (each within the scatter of the next).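

In this assay, replacing ((phenylsulfonyl)amino)methyl with ((2,6-difluorophenyl)carbonyl)amino on this saturated chain carbon gives a 1.7-fold higher number from compound 2 to compound 4 (0.22 log units; within the scatter), so the two compounds cannot be told apart. This exchange is a substantial one, swapping sulfur and its two oxygens for a single carbonyl, adding two fluorines to the ring and removing a methyl from the chain, yet the measured number does not separate the two structures. Nothing available explains this result.

Since these parts were exchanged together, the contribution of each one remains unresolved, and the step says nothing about any of them alone. From the compounds shown here alone, it is also open whether a different group at this place, such as a primary amine, a carboxylic acid or a longer chain, would move the number beyond the scatter.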